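The source may hold more compounds than are shown below. What is called first, only, known or untested is meant among the compounds shown, and "the series" means these compounds.

Measured so far in a functional assay on MCF7 cells (Homo sapiens) for antiproliferative activity, read by sulforhodamine B assay, with a stated time of 48 h; a lower number here means a stronger inhibitor, a higher number a weaker inhibitor:
compound 1 `COc1ccc(C[C@@H](O)/C=C/C=C/C(=O)NCc2ccc(Cl)cc2)cc1OC`: 18100 nM
compound 2 `COc1ccc(C[C@@H](O)/C=C/C=C/C(=O)N2CCCC2)cc1OC`: 26200 nM

Within the data shown here, compound 1 stands level with compound 2, the only other compound measured, a 1.4-fold higher number from compound 1 to compound 2 (0.16 log units; within the scatter). Compound 3 `COc1ccc(CNC(=O)/C=C/C=C/[C@H](O)Cc2ccc(OC)c(OC)c2)cc1` keeps the core of compound 1 but has methoxy in place of chloro on an aromatic carbon, (methoxy in place of chloro on an aromatic carbon). Among the measured compounds shown here, no measured step changes this group directly. The nearest evidence is pyrrolidin-1-yl in place of (4-chlorobenzyl)amino, which gave only a 1.4-fold higher number from compound 1 to compound 2 (0.16 log units; within the scatter). No step beyond the scatter is therefore expected, and the expected step is a 1.1-fold higher number from compound 1 to compound 3 (0.04 log units; within the scatter). Compound 3 is estimated at 20000 nM, with an expected range from 9000 nM to 45000 nM.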

Compound 3, half-maximal inhibitory concentration: 26600 nM
For compound 3 the middle estimate is 1.3-fold (0.12 log units) below the measured one; the measured number falls inside the stated range.
By their numbers in this assay, from the lowest: compounds 1, 2 and 3 (each within the scatter of the next).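

In this assay, among these compounds, methoxy in place of chloro on the aromatic carbon para to a large group gives a 1.5-fold higher number from compound 1 to compound 3 (0.17 log units; within the scatter) and so offers the first direct reading at this position. The 4-chlorobenzyl and 4-methoxybenzyl compounds cannot be told apart here, even though methoxy brings one more heavy atom and a hydrogen-bond acceptor. Nothing measured here accounts for this reading.

The compounds shown leave open whether a carboxylic acid or a dimethylamino group at this position would give a step beyond the scatter. They also leave open whether any change to the core of compound 1 would do so.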